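What a sulfonamide loses without its 4,6-dimethylpyrimidin-2-yl group

The compounds below may be only part of what the source reports. "The series", "measured", "known", "first", "only" and "open" are said of these compounds alone.

- Compound 1 `Cc1cc(C)nc(NS(=O)(=O)c2ccc(Nc3nncc4ccccc34)cc2)n1` gives 3.4 nM
- Compound 2 `S=C(NNc1nncc2ccccc12)Nc1ccccc1` gives 74 nM

In a functional assay on MDA-MB-435 cells (Homo sapiens) for antiproliferative activity, read by sulforhodamine B assay, with a stated time of 72 h (a lower number here means a stronger inhibitor, a higher number a weaker inhibitor), compound 1 gives 3.4 nM, the lower of the two numbers, and its gap to compound 2 lies beyond the scatter. Compound 3 `NS(=O)(=O)c1ccc(Nc2nncc3ccccc23)cc1` has hydrogen in place of 4,6-dimethylpyrimidin-2-yl on a sulfonamide nitrogen. Going by the values given here, no measured pair shows this change, so the expectation is only a rough one. The expected step is an 8.8-fold higher number from compound 1 to compound 3 (0.95 log units; beyond the scatter), towards a weaker inhibitor and beyond the scatter. Compound 3 is estimated at 30 nM, with an expected range from 4 nM to 250 nM.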

Compound 3, half-maximal inhibitory concentration: 18 nM
Beside the measured number, compound 3's estimate is 1.7-fold (0.22 log units) above it; the range from low to high includes it.
By their numbers in this assay, from the lowest: compound 1; then compound 3; then compound 2.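

In this assay, hydrogen in place of 4,6-dimethylpyrimidin-2-yl on the sulfonamide nitrogen brings a 5.3-fold higher number from compound 1 to compound 3 (0.72 log units; beyond the scatter), a modest loss beyond the scatter. The large group therefore adds to the strength at this position, but a low number does not depend on it: compound 3, with the bare sulfonamide, still gives 18 nM. Nothing available explains why the group helps. As far as these compounds go, whether a single methyl group or a pyridin-2-yl ring on that nitrogen would win back the lost strength stays open.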